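This account rests on a few compounds, and the source may have more. Where it says the series, first, only, none or still open, it means among the compounds named here.

Measured in an ADME assay on microsomes from liver (Rattus norvegicus) for metabolic stability; on this read-out higher numbers stand for a longer-lived compound and lower numbers for a shorter-lived compound:
- compound 1 `CCS(=O)(=O)c1ccc(CNC(=O)c2ccc3c(c2)cc(Cc2ccccc2Br)n3C(C)C)cc1`: 0.2 h
- compound 2 `CCS(=O)(=O)c1ccc(CNC(=O)c2ccc3c(c2)cc(Cc2ccccc2C(F)(F)F)n3C(C)C)cc1`: 0.717 h
- compound 3 `CCS(=O)(=O)c1ccc(CNC(=O)c2ccc3c(c2)cc(Cc2ccc(F)cc2C(F)(F)F)n3C(C)C)cc1`: 1.07 h

Compound 3, at 1.07 h, stands within the scatter of compound 2 and clear of compound 1. The next compound to be tested is compound 4 `CCc1ccccc1Cc1cc2cc(C(=O)NCc3ccc(S(=O)(=O)CC)cc3)ccc2n1C(C)C`. It differs from compound 3 by 2-ethylphenyl in place of 4-fluoro-2-(trifluoromethyl)phenyl on a saturated chain carbon bound to an aromatic carbon.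

Within the data shown here, no measured compound carries the ethyl group, so the evidence is indirect. Among the measured compounds shown here, three measured steps concern the same phenyl group. Trifluoromethyl in place of bromo gave a 3.6-fold higher number from compound 1 to compound 2 (0.55 log units; beyond the scatter), and the full replacement of the group gave a 5.4-fold higher number from compound 1 to compound 3 (0.73 log units; beyond the scatter). Fluoro in place of hydrogen gave only a 1.5-fold higher number from compound 2 to compound 3 (0.17 log units; within the scatter), so losing the fluoro alone is not expected to count for much. Compound 4 lacks trifluoromethyl, as does compound 1, which gives 0.2 h. A step down of modest size in this assay is therefore expected, though this rests on a single compound.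

The estimated step is a 3.1-fold lower number from compound 3 to compound 4 (0.49 log units; beyond the scatter). For compound 4 the expected half-life is 0.35 h, with an estimated range of 0.12 h to 0.9 h.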

Compound 4, half-life: 0.2 h
For compound 4 the middle estimate is 1.8-fold (0.24 log units) above the measured one; the measured number falls inside the stated range.
By their numbers in this assay, from the lowest: compounds 1 and 4 (each within the scatter of the next); then compounds 2 and 3 (each within the scatter of the next).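

In this assay, ethyl in place of trifluoromethyl on an aromatic carbon gives a 3.6-fold lower number from compound 2 to compound 4 (0.55 log units; beyond the scatter), while ethyl in place of bromo gives no change at the digits printed from compound 1 to compound 4 (within the scatter), and the full change of 4-fluoro-2-(trifluoromethyl)phenyl to 2-ethylphenyl gives a 5.4-fold lower number from compound 3 to compound 4 (0.73 log units; beyond the scatter). The earlier compounds set trifluoromethyl against bromo alone; now a second group, an all-carbon one, also falls short of trifluoromethyl at this place, so among these four compounds the two that carry trifluoromethyl, compound 2 and compound 3, hold the higher numbers and none goes against that. Nothing measured here says why the half-life follows this group.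

From the compounds shown here alone, what remains open is how far this split extends to other groups at this place, such as methyl, methoxy, chloro, a nitrile or a longer chain, since bromo, ethyl and trifluoromethyl are the only three compared so far. Going by these compounds, it is also open whether a 4-fluoro group would do any more on the 2-ethylphenyl ring than it did on the ring that carries trifluoromethyl.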